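The compounds below may be only part of what the source reports. "The series", "measured", "known", "first", "only" and "open" are said of these compounds alone.

Measured so far in an assay on isolated protein for inhibition of Ephrin type-A receptor 2 (Homo sapiens), read by thermal shift assay, tested at 10 uM; a higher number here means that the compound stabilises the target more against heat, a lower number that the compound stabilises the target less:
compound 1 `CCOc1ccc(NC(=O)Nc2cc(C(C)(C)C)nn2-c2ccccc2)cc1`: 1 degrees C
compound 2 `CC(C)(C)c1cc(NC(=O)Nc2ccccc2)n(-c2ccccc2)n1`: 1.6 degrees C

Among the measured compounds shown here, the only measured step, a number 0.60 degrees C higher from compound 1 to compound 2 (within the scatter), changes the ring on the other side of the urea. On the numbers shown compound 2 stands at the top of the two, with compound 1 nearest, but that gap is within the scatter, so the two compounds cannot be told apart in this assay.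

Compound 3 `CC(C)(C)c1cc(NC(=O)Nc2cc(F)cc(F)c2)n(-c2ccccc2)n1` differs from compound 2 by 3,5-difluorophenyl in place of phenyl on an amide-type nitrogen. For the measured compounds named here, no measured step touches this ring: the step from compound 1 to compound 2 concerns the ethoxy-bearing ring, not the phenyl on the amide-type nitrogen, so nothing here tells how this change will read. Going by the values given here, with no bearing step, the expectation is no movement beyond the scatter. Compound 3 is therefore estimated at 1.6 degrees C, within 0.4 degrees C to 2.8 degrees C, an expected step of no change at the digits printed from compound 2 to compound 3 (within the scatter).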

Compound 3, shift of the target's melting temperature: 2.7 degrees C
Estimate against measurement, compound 3: 1.1 degrees C below; measured number inside the range.
By their numbers in this assay, from the lowest: compounds 1 and 2 (each within the scatter of the next); then compound 3.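

In this assay the ring on the amide-type nitrogen turns out to be a place where a change can register: 3,5-difluorophenyl in place of phenyl gives a number 1.1 degrees C higher from compound 2 to compound 3 (beyond the scatter) and so moves the read-out beyond the scatter, which the earlier step did not do. The same group in place of 4-ethoxyphenyl gives a number 1.7 degrees C higher from compound 1 to compound 3 (beyond the scatter) and thus sets compound 3 apart from both earlier compounds, which could not be told apart from each other. Nothing available accounts for this gain.

The compounds shown leave open whether a single fluorine would serve as well as two, and whether chlorine or a methoxy group on this ring would read the same. They also leave open how the read-out would respond to an amine or a carboxylic acid on this ring.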